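The source may hold more compounds than are shown below. What is called first, only, known or untested is meant among the compounds shown, and "the series" means these compounds.

The measured compounds in this study are:

Compound 1, `N[C@H]1CC[C@H](Nc2c(C(=O)NCc3ccc(Cl)cc3Cl)nc(Br)c3cccnc23)CC1`, with 6000 nM in a functional assay on SK-BR-3 cells (Homo sapiens) for cytotoxicity, read by MTT assay, with a stated time of 72 h; a lower number here means a stronger inhibitor, a higher number a weaker inhibitor.
Compound 2, `N[C@H]1CC[C@H](Nc2c(C(=O)NCc3cccs3)nc(Br)c3cccnc23)CC1`, with "not determined" (no result reported) in this assay, meaning that no result was reported.
Compound 3, `COc1ccc(CNC(=O)c2nc(Br)c3cccnc3c2N[C@H]2CC[C@H](N)CC2)cc1`, with 5000 nM in this assay.

Compound 3 and compound 1 share the same core and differ only in the aryl group on the saturated chain carbon bound to the amide-type nitrogen. Their values lie within the scatter of each other: a 1.2-fold lower number from compound 1 to compound 3 (0.08 log units; within the scatter). Compound 3 thus holds no distinct position among the two reported numbers.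

Compound 4, `N[C@H]1CC[C@H](Nc2c(C(=O)Nc3ccccc3)nc(Br)c3cccnc23)CC1`, has not yet been measured in this assay. It differs from compound 3 as follows: phenyl in place of 4-methoxybenzyl on an amide-type nitrogen. Among the measured compounds shown here, the only measured step that bears on this region is the one from compound 1 to compound 3, which exchanged one aryl group for another on that saturated chain carbon and stayed within the scatter. For the measured compounds named here, the change to compound 4 goes further, removing the saturated chain carbon altogether, so no measured step covers it directly.

Compound 4 is therefore expected to show a step of a 1.1-fold higher number from compound 3 to compound 4 (0.04 log units; within the scatter) that stays within the scatter. Compound 4 is estimated at 5500 nM, with a range from 2000 nM to 15000 nM.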

Compound 4, half-maximal inhibitory concentration: 2000 nM
Compound 4: middle estimate off by 2.8-fold (0.44 log units), on the high side; the range from low to high includes it.
By their numbers in this assay, from the lowest: compound 4; then compounds 3 and 1 (each within the scatter of the next).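

In this assay, the amide-type nitrogen proves more responsive to a change in what is attached directly to it than the earlier comparison suggested: exchanging one aryl group for another on the saturated chain carbon had stayed within the scatter, whereas phenyl in place of 4-methoxybenzyl gives a 2.5-fold lower number from compound 3 to compound 4 (0.40 log units; beyond the scatter). Phenyl in place of 2,4-dichlorobenzyl points the same way and gives a 3.0-fold lower number from compound 1 to compound 4 (0.48 log units; beyond the scatter), so both substituted benzyl compounds, which cannot be told apart from each other, are separated from the anilide compound 4 by modest steps beyond the scatter. No supporting measurement is available to explain this difference in the cytotoxicity read-out.

Both steps change the ring substitution and remove the saturated chain carbon at once, so the compounds shown cannot say which of the two changes carries the difference; an unsubstituted benzyl group on the same nitrogen would separate them. From the compounds shown here alone, it also remains open whether the trend continues with a longer chain, such as 2-phenylethyl, or how a methoxy or chloro substituent would behave on the phenyl ring of the anilide itself.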